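A few compounds are considered here, and "the series" means these few. Any claim that something is new, unique, unknown or untested is made for them only; others in the source may bear on it.

Measured compounds in a functional assay on A549 cells (Homo sapiens) for cytotoxicity, read by MTT assay, with a stated time of 48 h; a higher number here means a weaker inhibitor, a lower number a stronger inhibitor:
Compound 1, `O=C(O)CN1C(=O)/C(=C/c2nc3ccccc3n2Cc2ccc(F)cc2)SC1=S`, gives 3570 nM.
Compound 2, `O=C(O)CN1C(=O)/C(=C/c2nc3ccccc3n2Cc2ccc(Cl)cc2)SC1=S`, gives 17500 nM.
Compound 3, `O=C(O)CN1C(=O)/C(=C/c2nc3ccc(Cl)cc3n2Cc2ccccc2F)SC1=S`, gives 26900 nM.

One step is counted: a 4.9-fold lower number from compound 2 to compound 1 (0.69 log units; beyond the scatter), the change being (fluoro in place of chloro on an aromatic carbon). The difference between the cores of compound 2 and compound 3 is not broken down here; their two values lie within the scatter of each other, while compound 1 stands beyond the scatter below both.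

Compound 4, `O=C(O)CN1C(=O)/C(=C/c2nc3ccc(F)cc3n2Cc2ccccc2F)SC1=S`, differs from compound 3 by fluoro in place of chloro on an aromatic carbon. This is the same kind of change as that from compound 2 to compound 1, not the same: there the place was an aromatic carbon para to a large group, here it is part of a fused or bridged system of two rings, meta and para to a fused ring. Compound 4 is expected to show a 2.2-fold lower number from compound 3 to compound 4 (0.35 log units; beyond the scatter), a smaller step than the one counted, because a 4.9-fold lower number from compound 2 to compound 1 (0.69 log units; beyond the scatter) sits at a different place. Compound 4 is estimated at 12000 nM, between 4000 nM and 35000 nM.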

Compound 4, half-maximal inhibitory concentration: > 50000 nM
Compound 4 ended at the assay's limit; the forecaster's own chance of this, stated with the estimate: 10%; middle value at least 4.1-fold (0.61 log units) from the limit.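

In this assay compound 4 gives > 50000 nM, which is a limit of the assay and not a number. Fluoro in place of chloro gives an at least 1.8-fold higher number from compound 3 to compound 4 (0.26 log units; that floor lies within the scatter), so the change does not carry over unaltered from the earlier core to this one: the same change on two cores in this assay, a 4.9-fold lower number (0.69 log units; beyond the scatter) from compound 2 to compound 1 and an at least 1.8-fold higher number (0.26 log units; that floor lies within the scatter) from compound 3 to compound 4, at least 9.1-fold (0.95 log units) apart, beyond the scatter of two such steps This rests on only two pairs, with the change at a different place in each, so it does not show what separates the two steps, and the full size of the new step remains unknown.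

The compounds shown leave open how a bromo or methoxy group would read at either place. They also leave open whether an ester or amide in place of the carboxylic acid would alter these steps.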